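A few compounds are considered here, and "the series" means these few. Any claim that something is new, unique, unknown or untested is made for them only; others in the source may bear on it.

Three compounds share one core and differ only in the group attached to an amide-type nitrogen. Compound 1 `COc1cc(-c2cc(C(=O)O)c3ccccc3n2)ccc1OCC(=O)Nc1ccccc1F` carries a 2-fluorophenyl there and in a physicochemical assay for lipophilicity, using the shake flask method, in phosphate buffer, measured as octanol-water partition, at pH 7.4 (on this read-out lower numbers stand for lower lipophilicity and higher numbers for higher lipophilicity), compound 1 gives 0.9. Compound 2 `COc1cc(-c2cc(C(=O)O)c3ccccc3n2)ccc1OCC(=O)Nc1ccc(C(F)(F)F)cc1` carries a 4-(trifluoromethyl)phenyl and in this assay compound 2 gives 1.6. Compound 3 `COc1cc(-c2cc(C(=O)O)c3ccccc3n2)ccc1OCC(=O)NCc1ccccc1` carries a benzyl and in this assay compound 3 gives 0.4. Compound 1 thus stands second highest of the three: the step of a number 0.70 log units higher from compound 1 to compound 2 (beyond the scatter) runs upward, and the step of a number 0.50 log units lower from compound 1 to compound 3 (beyond the scatter) runs downward.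

Compound 4 `COc1cc(-c2cc(C(=O)O)c3ccccc3n2)ccc1OCC(=O)NCc1cccnc1` is the unmeasured partner of compound 1. The change between them is (pyridin-3-yl)methyl in place of 2-fluorophenyl on an amide-type nitrogen.

Among the measured compounds shown here, the step that bears most directly on this is the one from compound 1 to compound 3, where a benzyl replaced the same 2-fluorophenyl and gave the modest drop quoted above. Compound 4 goes one step further than compound 3: its group is also a methyl-linked ring, but the ring now holds one nitrogen and brings one hydrogen-bond acceptor, which on this kind of read-out usually pulls the number further down. For the measured compounds named here, the expected step is therefore downward, beyond the scatter, and larger than the one to compound 3, about a number 1.20 log units lower from compound 1 to compound 4 (beyond the scatter). For compound 4 the estimated value in this assay is -0.3, expected to fall between -0.9 and 0.3.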

Compound 4, distribution coefficient: -0.8
Compound 4: the middle estimate sits 0.50 log units above what was measured; measured number inside the range.
By their numbers in this assay, from the lowest: compound 4; then compound 3; then compound 1; then compound 2.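

In this assay, among the compounds shown here, the swap of pyridin-3-yl for phenyl, with the methyl link kept in place, gives a number 1.20 log units lower from compound 3 to compound 4 (beyond the scatter), which isolates the ring change for the first time. That single change is a large step, while the swap of benzyl for 2-fluorophenyl gave only the modest a number 0.50 log units lower from compound 1 to compound 3 (beyond the scatter), so most of the full change, a number 1.70 log units lower from compound 1 to compound 4 (beyond the scatter), comes with the ring and not with the move to a methyl-linked group. The series now also spans a wider range at this amide-type nitrogen, with the widest gap being a number 2.40 log units lower from compound 2 to compound 4 (beyond the scatter), and nothing available explains why the ring change has so large an effect.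

From the compounds shown here alone, it remains open whether pyridin-2-yl or pyridin-4-yl on the same methyl link would give a number close to that of compound 4, which would show whether the place of the ring nitrogen matters. Also open, going by these compounds, is how pyridin-3-yl would read when bound directly to the amide-type nitrogen or carried on a longer chain, and whether a saturated amine such as piperidine would follow the same trend.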